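Moving a methoxy group around the aryl ring

The source may report more compounds than this note shows. Statements on the series, on what has been measured and on what is new or still open speak of the compounds shown alone.

Of the compounds shown here, three sharing one core have been tested in an assay on isolated protein for inhibition of ribosomal protein S6 kinase alpha-5 (Homo sapiens), read by mobility shift assay, tested at 30 uM; a lower number here means less inhibition, a higher number more inhibition at the concentration tested (going by the name of the read-out). Compound 1 `CC(C)(C)c1cc2nn(-c3ccccc3)c(N)c2c(=O)[nH]1` gives -1%, compound 2 `Nc1c2c(=O)[nH]c(-c3ccccn3)cc2nn1-c1ccccc1` gives 4%, and compound 3 `COc1ccccc1-c1cc2nn(-c3ccccc3)c(N)c2c(=O)[nH]1` gives 7%. The differences between them, a number 8 percentage points higher from compound 1 to compound 3 (within the scatter) and a number 3 percentage points higher from compound 2 to compound 3 (within the scatter), are both within the scatter, so compound 3 cannot be separated from the other two on these numbers.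

Compound 4 `COc1ccc(-c2cc3nn(-c4ccccc4)c(N)c3c(=O)[nH]2)cc1` differs from compound 3 by 4-methoxyphenyl in place of 2-methoxyphenyl on an aromatic carbon. Among the measured compounds shown here, no measured step swaps one methoxyphenyl isomer for another; the nearest comparisons are the aryl exchanges at the same position, which all stayed within the scatter. Compound 4 is therefore expected to show a number 2 percentage points lower from compound 3 to compound 4 (within the scatter), giving an estimated 5% in this assay, within a range from -6% to 16%.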

Compound 4, a percentage reported as inhibition, at one concentration (the size of the read-out at that concentration, not a potency): 6%
For compound 4 the middle estimate is 1 percentage points below the measured one, and the stated range covers the measured number.
By their numbers in this assay, from the lowest: compounds 1, 2, 4 and 3 (each within the scatter of the next).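

In this assay, moving the methoxy group gives a number 1 percentage points lower from compound 3 to compound 4 (within the scatter), so 4-methoxyphenyl and 2-methoxyphenyl cannot be told apart at this position. The other comparisons, a number 2 percentage points higher from compound 2 to compound 4 (within the scatter) and a number 7 percentage points higher from compound 1 to compound 4 (within the scatter), add that 4-methoxyphenyl also cannot be separated from pyridin-2-yl or tert-butyl. Nothing given here offers a reason for these numbers.

Still open, going by these compounds, is whether an amine or a carboxylic acid on this aryl ring would move the number in this assay beyond the scatter.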